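The source may report more compounds than this note shows. Statements on the series, on what has been measured and on what is new or still open speak of the compounds shown alone.

Measured in a functional assay on SK-LU-1 cells (Homo sapiens) for antiproliferative activity, read by sulforhodamine B assay, with a stated time of 48 h, tested at 50 uM (on this read-out higher numbers stand for more inhibition at the one concentration tested (going by the name of the read-out) and lower numbers for less inhibition), so far:
- compound 1 `Cc1cc2c(C(C)C)ccc(C)c2cc1OC(=O)c1ccc(C(F)(F)F)cc1`: 28.7%
- compound 2 `CC1=CC[C@H](C(C)C)c2cc(C)c(OC(=O)c3ccccc3)cc21`: 37%
- compound 3 `CC1=CC[C@H](C(C)C)c2cc(C)c(OC(=O)c3ccc(C(F)(F)F)cc3)cc21`: "not active" (no number reported)

Compound 2 carries the higher of the two numbers in this assay, yet its gap to compound 1 sits within the scatter, so no order between the two can be read. Compound 3, with a trifluoromethyl on the benzoate, gave no number at all. Within the data shown here, no single-change step between measured compounds exists here.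

Compound 4 `CC1=CC[C@H](C(C)C)c2cc(C)c(OC(=O)c3cccc([N+](=O)[O-])c3)cc21` differs from compound 2 by nitro in place of hydrogen on an aromatic carbon. Compound 3, carrying a substituent on the benzoate, is reported as not active in this assay. On that ground a downward step is expected, a number 13 percentage points lower from compound 2 to compound 4 (beyond the scatter), of moderate size but uncertain. Compound 4 is therefore estimated at 24%, within 5% to 42%.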

Compound 4, a percentage reported as inhibition, at one concentration (the size of the read-out at that concentration, not a potency): 60.4%
The estimate for compound 4 lay 36.4 percentage points below the measured number; the whole stated range lies below it.
By their numbers in this assay, from the lowest: compounds 1 and 2 (each within the scatter of the next); then compound 4.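

In this assay, phenyl to 3-nitrophenyl gives a number 23.4 percentage points higher from compound 2 to compound 4 (beyond the scatter), the first single-change step readable in this series. The position meta to a large group therefore accepts nitro with a gain on this read-out, and a substituent on this aromatic ring need not end in a "not active" report. No measurement bears on why the step occurs.

From the compounds shown here alone, whether an amine or a carboxylic acid on the same carbon would give a step of similar size remains open. Also open, going by these compounds, is whether nitro would raise the number on the core of compound 1.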